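Sulfonyl substituent variation in the aryl-alkyne acid series

The source may hold more compounds than are shown below. What is called first, only, known or untested is meant among the compounds shown, and "the series" means these compounds.

Measured so far:
- compound 1 `COCCN(C)S(=O)(=O)c1ccc(C)c(C#Cc2cc(Cl)ccc2OCC(=O)O)c1`; in an assay on CHO cells for displacement of a labelled ligand from prostaglandin D2 receptor 2 (Homo sapiens), read by scintillation counting (on this read-out higher numbers stand for weaker inhibition and lower numbers for stronger inhibition), compound 1 gives 4.1 nM
- compound 2 `CS(=O)(=O)c1ccc(F)c(C#Cc2cc(Cl)ccc2OCC(=O)O)c1`; in this assay compound 2 gives 3.3 nM
- compound 3 `CC1(O)c2ccc(C#Cc3cc(Cl)ccc3OCC(=O)O)cc2S(=O)(=O)C1(C)C`; in this assay compound 3 gives 28 nM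

Compound 1 stands second highest of the three numbers. Compound 2 lies closest, and the two values sit within the usual scatter, so nothing separates them. Compound 3 gives a clearly higher number than compound 1, a gap beyond the scatter.

Compound 4 `Cc1ccc(S(=O)(=O)CCO)cc1C#Cc1cc(Cl)ccc1OCC(=O)O` is the next point and has not yet been measured in this assay. It differs from compound 1 in one place: 2-hydroxyethyl in place of (2-methoxyethyl)(methyl)amino on a sulfonyl sulfur. The comparison of compound 1 with compound 2 shows that exchanging the sulfonyl substituent in this part of the shared core need not move the number beyond the scatter, so the expected step is small and without a clear direction: a 1.2-fold higher number from compound 1 to compound 4 (0.09 log units; within the scatter). On that basis compound 4 is expected to give about 5 nM in this assay, with a likely range from 2 nM to 15 nM.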

Compound 4, inhibition constant: 19 nM
Beside the measured number, compound 4's estimate is 3.8-fold (0.58 log units) below it, and the stated range ends below it.
By their numbers in this assay, from the lowest: compounds 2 and 1 (each within the scatter of the next); then compounds 4 and 3 (each within the scatter of the next).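

In this assay, 2-hydroxyethyl in place of (2-methoxyethyl)(methyl)amino on a sulfonyl sulfur gives a 4.6-fold higher number from compound 1 to compound 4 (0.67 log units; beyond the scatter) and so shows that the number responds to this substituent. For the compounds shown here, this is the first step with only this one place changed, so the sensitivity is read directly, not inferred from compounds that differ in several places. The exchange removes the nitrogen, goes from 6 heavy atoms to 3 and brings in a hydrogen-bond donor all at once, and no evidence at hand separates these changes.

Open, from the compounds shown here alone, is whether (2-hydroxyethyl)(methyl)amino or 2-methoxyethyl on the sulfonyl sulfur would track compound 1 or compound 4, which would separate the nitrogen from the hydroxyl. Also open, going by these compounds, is how a longer chain such as 3-hydroxypropyl would read there.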